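Replacing the benzyl group on the ring nitrogen of compound 1

A few compounds are considered here, and "the series" means these few. Any claim that something is new, unique, unknown or untested is made for them only; others in the source may bear on it.

Compound 1, `NC(=O)c1c(NC(=O)c2ccccc2Cl)sc2c1CCN(Cc1ccc(Cl)cc1)C2`, carries a 4-chlorobenzyl group on the amine nitrogen in its ring. In a functional assay on MKN-74 cells (Homo sapiens) for antiproliferative activity, with a stated time of 24 h (on this read-out lower numbers stand for stronger inhibition and higher numbers for weaker inhibition), compound 1 gives 18700 nM, the highest of the two numbers reported, while compound 3, `NC(=O)c1c(NC(=O)c2cccc([N+](=O)[O-])c2)sc2c1CCN(Cc1c(Cl)cccc1Cl)C2`, gives 13500 nM, which sits within the scatter of compound 1. Compound 2, `NC(=O)c1c(NC(=O)c2ccc(C(F)(F)F)cc2)sc2c1CCN(Cc1ccc(Cl)cc1)C2`, gives only a limit, > 50000 nM. Among the measured compounds shown here, the one measured step, an at least 2.6-fold higher number from compound 1 to compound 2 (0.42 log units; beyond the scatter), concerns the aryl group on the carbonyl carbon and is bounded by the limit of > 50000 nM in this assay, at which 1 of the 3 values shown sits. Compound 4, `Cc1ccccc1NC(=S)N1CCc2c(sc(NC(=O)c3ccccc3Cl)c2C(N)=O)C1`, differs from compound 1 at a different place: a group of 10 heavy atoms (8 carbon, 1 nitrogen, 1 sulfur; one six-membered aromatic ring of carbon only) in place of a group of 8 heavy atoms (7 carbon, 1 chlorine; one six-membered aromatic ring of carbon only), on an amine nitrogen in a ring. For the measured compounds named here, no measured step touches the group on the amine nitrogen, so there is no basis for expecting a change beyond the scatter in either direction. Compound 4 is therefore expected to give about 20000 nM in this assay, between 6000 nM and 60000 nM, an estimated step of a 1.1-fold higher number from compound 1 to compound 4 (0.03 log units; within the scatter).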

Compound 4, half-maximal inhibitory concentration: 11700 nM
Compound 4: middle estimate off by 1.7-fold (0.23 log units), on the high side; low and high end bracket the measured number.
By their numbers in this assay, from the lowest: compounds 4, 3 and 1 (each within the scatter of the next). At a limit, above all of these: compound 2.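

Among the compounds shown here, this is the first measured change at the amine nitrogen in the ring, and in this assay it gives a 1.6-fold lower number from compound 1 to compound 4 (0.20 log units; within the scatter). The 4-chlorobenzyl group can thus give way to a larger group, one with a double bond outside aromatic rings, a hydrogen-bond donor and a hydrogen-bond acceptor, without the number leaving the scatter, at least for this pair with the 2-chlorophenyl group kept on the carbonyl carbon. Nothing given here accounts for the size of this step.

The compounds shown leave open whether a group of another kind on this nitrogen, such as a carboxylic acid, an amine or a longer alkyl chain, would move the number beyond the scatter. They also leave open whether the same exchange would give a similar step with a different aryl group on the carbonyl carbon.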